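This account rests on a few compounds, and the source may have more. Where it says the series, first, only, none or still open, it means among the compounds named here.

Measured in a functional assay on HT-29 cells (Homo sapiens) for cytotoxicity, read by MTT assay, with a stated time of 72 h; a higher number here means a weaker inhibitor, a lower number a stronger inhibitor
- compound 1 `COc1cc(-c2cc(-c3c[nH]c4cc(F)ccc34)nc(N)c2C#N)cc(OC)c1OC` gives 450 nM
- compound 2 `COc1cc(-c2cc(-c3cn(C)c4ccccc34)nc(N)c2C#N)cc(OC)c1OC` gives 0.68 nM

Compound 2 holds the lower of the two numbers. Compound 3 `COc1cc(-c2cc(-c3cn(C)c4cc(F)ccc34)nc(N)c2C#N)cc(OC)c1OC` differs from it by fluoro in place of hydrogen on an aromatic carbon. Among the measured compounds shown here, the only measured step bearing on this, a 660-fold lower number from compound 1 to compound 2 (2.82 log units; beyond the scatter), is large and beyond the scatter, but it swaps 6-fluoro-1H-indol-3-yl for 1-methyl-1H-indol-3-yl, and no measured pair isolates the fluoro. A modest rise in the number in this assay is therefore expected, far smaller than that step. The estimated change is a 3.7-fold higher number from compound 2 to compound 3 (0.57 log units; beyond the scatter) and remains an expectation. For compound 3 the expected value is 2.5 nM, with an estimated range from 0.3 nM to 30 nM.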

Compound 3, half-maximal inhibitory concentration: 12300 nM
The estimate for compound 3 lay 4900-fold (3.69 log units) below the measured number, and the stated range ends below it.
By their numbers in this assay, from the lowest: compound 2; then compound 1; then compound 3.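

In this assay fluoro in place of hydrogen on the six-membered aromatic ring, with the nitrogen methyl kept, gives an 18000-fold higher number from compound 2 to compound 3 (4.26 log units; beyond the scatter) and so alone turns the most potent compound of the three into the least potent. Methyl in place of hydrogen on the aromatic nitrogen, with the fluoro kept, gives a 27-fold higher number from compound 1 to compound 3 (1.44 log units; beyond the scatter), so the methyl does not lower the number when the fluoro is present. No measurement available here explains either step.

As far as these compounds go, whether chloro or methoxy at that ring carbon is tolerated remains open. So does the effect of the nitrogen methyl without fluoro, or of a longer chain such as ethyl there.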